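Aryl ether for biaryl on the shared quinoline-free core

The source may hold more compounds than are shown below. What is called first, only, known or untested is meant among the compounds shown, and "the series" means these compounds.

Measured in an ADME assay for permeability, using PAMPA, with a stated time of 30 min, at pH 7.4; a higher number here means that the compound crosses the layer faster, a lower number that the compound crosses the layer more slowly:
compound 1 `COc1cccc(CNCCCNc2ccnc3cc(Oc4cccc(N(C)C)c4)ccc23)c1O` gives 317 10^-6 cm/s
compound 2 `COc1cccc(CNCCCNc2ccnc3cc(CC(C)C)ccc23)c1O` gives 23 10^-6 cm/s
compound 3 `COc1ccc(-c2ccc3c(NCCCNCc4cccc(OC)c4O)ccnc3c2)cc1` gives 237 10^-6 cm/s

Compound 3 sits alongside compound 1, since a 1.3-fold lower number from compound 1 to compound 3 (0.13 log units; within the scatter) stays within the scatter, while a 10-fold higher number from compound 2 to compound 3 (1.01 log units; beyond the scatter) and a 14-fold lower number from compound 1 to compound 2 (1.14 log units; beyond the scatter) show that compound 2 stands far below both.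

Compound 4 `COc1ccccc1Oc1ccc2c(NCCCNCc3cccc(OC)c3O)ccnc2c1` differs from compound 3 by 2-methoxyphenoxy in place of 4-methoxyphenyl on an aromatic carbon. The step that bears on it is a 1.3-fold lower number from compound 1 to compound 3 (0.13 log units; within the scatter), where an aryloxy and an aryl group on the same carbon gave numbers within the scatter of each other, whereas only the isobutyl of compound 2 moved the number strongly. Compound 4 is therefore expected to show no step beyond the scatter in this assay, a 1.1-fold higher number from compound 3 to compound 4 (0.02 log units; within the scatter). Compound 4 is estimated at 250 10^-6 cm/s, with a range from 120 10^-6 cm/s to 500 10^-6 cm/s.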

Compound 4, apparent permeability: 317 10^-6 cm/s
Estimate against measurement, compound 4: 1.3-fold (0.10 log units) below; the measured number falls inside the stated range.
By their numbers in this assay, from the lowest: compound 2; then compounds 3, 1 and 4 (each within the scatter of the next).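

In this assay, a second aryloxy group at this position stays within the scatter of both aromatic comparators: a 1.3-fold higher number from compound 3 to compound 4 (0.13 log units; within the scatter), and no change at the digits printed from compound 1 to compound 4 (within the scatter). On the oxygen, 2-methoxyphenyl thus reads the same as 3-(dimethylamino)phenyl, while a 14-fold higher number from compound 2 to compound 4 (1.14 log units; beyond the scatter) shows that compound 2 remains the only one apart. Nothing given accounts for these numbers.

From the compounds shown here alone, it stays open whether a carboxylic acid on the aromatic ring of the aryloxy group would keep the number with compounds 1, 3 and 4. Also open, going by these compounds, is where a morpholine or a chain longer than isobutyl, on the same carbon, would stand.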